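Chlorophenyl to Chlorohydroxyphenyl: an Expected Cytotoxicity Value

A few compounds are considered here, and "the series" means these few. Any claim that something is new, unique, unknown or untested is made for them only; others in the source may bear on it.

Compound 1, `COc1cccc(/C=C2\CCC/C(=C\c3cccc(Br)c3)C2=O)c1OC`, in a functional assay on A549 cells (Homo sapiens) for cytotoxicity, read by MTT assay, with a stated time of 72 h (on this read-out lower numbers stand for stronger inhibition and higher numbers for weaker inhibition), gives > 20000 nM, which is a limit of the assay.
Compound 2, `COc1ccc(/C=C2\CCC/C(=C\c3cccc(OC)c3OC)C2=O)cc1`, in this assay gives > 20000 nM, again a limit.
Compound 3, `COc1ccc(/C=C2\CCC/C(=C\c3ccc(Cl)cc3)C2=O)cc1OC`, in this assay gives 10100 nM.

Within the data shown here, compound 3 therefore stands as the only compound with a definite number; the other two results rest at the limit of > 20000 nM in this assay, at which 2 of the 3 values shown sit. Among the measured compounds shown here, the single step that links two measured compounds, a step that the two limits leave unreadable from compound 1 to compound 2, cannot be read because both of its ends are limits, so no measured step gives a usable size for any change of the aryl group.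

Compound 4, `COc1ccc(/C=C2\CCC/C(=C\c3ccc(O)c(Cl)c3)C2=O)cc1OC`, differs from compound 3 in one place: 3-chloro-4-hydroxyphenyl in place of 4-chlorophenyl on a double-bonded chain carbon bound to a double-bonded ring carbon. For the measured compounds named here, no measured pair shows what adding a hydroxyl to the aryl group does, so the expectation rests only on compound 3 itself and on the modest size of the change. The step from compound 3 to compound 4 is expected to be a 1.4-fold lower number from compound 3 to compound 4 (0.16 log units; within the scatter), that is, no clear shift beyond the usual scatter in either direction. On that basis compound 4 is estimated at 7000 nM, with a plausible range from 2500 nM to 20000 nM.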

Compound 4, half-maximal inhibitory concentration: > 20000 nM
Compound 4: a limit, no number; the forecaster's own chance of this, stated with the estimate: 30%; at least 2.8-fold (0.45 log units) between middle value and limit.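

Among these compounds, this is the first step on the aryl group at this place, on a double-bonded chain carbon bound to a double-bonded ring carbon, that gives any size at all: in this assay, 3-chloro-4-hydroxyphenyl in place of 4-chlorophenyl gives an at least 1.9-fold higher number from compound 3 to compound 4 (0.29 log units; that floor lies within the scatter). That size is only a floor, so the real step may be larger, but what can be read does not go beyond the usual scatter: the change brings no gain here and only hints at a loss. Among the compounds shown here, compound 3 remains the only compound with a definite number, while compound 4 is a limit and joins the other two: the limit of > 20000 nM in this assay, at which 3 of the 4 values shown sit.

Going by these compounds, whether the step comes from the hydroxyl itself or from the shifted chlorine stays open, as compound 4 differs from compound 3 in both; a 4-hydroxyphenyl or a 3-chlorophenyl group at this place would tell the two apart. Also open, on these data alone, is how this place responds to a group of another kind, such as an aminophenyl or a carboxyphenyl group, in place of 4-chlorophenyl.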